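The source may hold more compounds than are shown below. What is called first, only, known or untested is meant among the compounds shown, and "the series" means these compounds.

Measured so far:
- Compound 1, `COC(=O)c1ccc(OCCCCOc2ccc(C(=O)CC3CCCC3)c(O)c2C)cc1`, gives 22%
- Compound 2, `COC(=O)c1ccc(OCCCCOc2ccc(C(=O)CC3CCCC3)c(C)c2C)cc1`, gives 24.2%
- Compound 3, `COC(=O)c1ccc(OCCCCOc2ccc(C(=O)CC(C)C)c(O)c2C)cc1`, gives 22.7%

All three were read in an assay on HEK293 cells for positive allosteric modulation of metabotropic glutamate receptor 3 (Rattus norvegicus), read by thallium flux, with a stated time of 2.5 min; on this read-out lower numbers stand for smaller maximal responses and higher numbers for larger maximal responses. Compound 3 stands second highest of the three numbers, but its closest neighbour is compound 1, and the step of a number 0.7 percentage points higher from compound 1 to compound 3 (within the scatter) is within the scatter, so the two cannot be told apart. Compound 2 sits a little higher than compound 3, again by an amount that the values show to be small. The other measured step, a number 2.2 percentage points higher from compound 1 to compound 2 (within the scatter), is also within the scatter.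

Compound 4, `Cc1cc(OCCCCOc2ccc(C(=O)CC(C)C)c(O)c2C)ccc1C(=O)O`, is the next compound. Compared with compound 3 the change is 4-carboxy-3-methylphenyl in place of 4-(methoxycarbonyl)phenyl on an oxygen on a saturated carbon. Neither measured step bears on this part of the molecule: one changed hydroxy to methyl on the aromatic ring of the shared core, the other changed the cyclopentyl to isopropyl, and both stayed within the scatter. Among the compounds with values here, with no step touching this end of the chain, the expectation is no change beyond the scatter, a number 0.7 percentage points lower from compound 3 to compound 4 (within the scatter). Compound 4 is therefore estimated at 22%, with a range from 8% to 36%.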

Compound 4, largest response reached (reported as percent of maximum), in percent of the reference or control that the assay uses: 41.9%
Estimate against measurement, compound 4: 19.9 percentage points below; measured number above the stated range.
By their numbers in this assay, from the lowest: compounds 1, 3 and 2 (each within the scatter of the next); then compound 4.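

Within the data shown here, changing the group on the oxygen at the far end of the chain is the first change here to move the number in this assay beyond the scatter: 4-carboxy-3-methylphenyl in place of 4-(methoxycarbonyl)phenyl gives a number 19.2 percentage points higher from compound 3 to compound 4 (beyond the scatter). The earlier steps, at the hydroxy on the shared core and at the cyclopentyl, stayed within the scatter, so among these compounds this end of the molecule is the only place where the maximal response shifts measurably. No available evidence explains the rise.

This one step both turns the ester into a free carboxy group and adds a methyl to the ring, and the compounds shown cannot separate the two changes. A plain 4-carboxyphenyl group, without the methyl, or a primary amide in place of the carboxy group would help show which part of the change carries the step.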